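Sulfation Steps on a Lipoic-Acid-Linked Sulfated Oligosaccharide Series

The compounds below may be only part of what the source reports. "The series", "measured", "known", "first", "only" and "open" are said of these compounds alone.

The series is built on a disulfide-carrying aryl amide tethered through an open-chain polyol to a disaccharide bearing acetamido, carboxylic acid and sulfooxy groups. Compound 1 `CC(=O)N[C@H]1[C@@H](OC[C@@H](O)[C@@H](O)[C@H](O)[C@@H](O)CNc2cccc(NC(=O)CCCCC3CCSS3)c2)O[C@H](CO)[C@H](O)[C@@H]1O[C@@H]1O[C@H](C(=O)O)[C@@H](O)[C@H](O)[C@H]1OS(=O)(=O)O` was tested in an assay on isolated protein for binding affinity to fibroblast growth factor 2 (Homo sapiens), read by surface plasmon resonance (on this read-out higher numbers stand for weaker binding and lower numbers for tighter binding), and gave 62 nM. Compound 3 `CC(=O)N[C@H]1[C@@H](OC[C@@H](O)[C@@H](O)[C@H](O)[C@@H](O)CNc2cccc(NC(=O)CCCCC3CCSS3)c2)O[C@H](CO)[C@H](O)[C@@H]1O[C@@H]1O[C@H](C(=O)O)[C@@H](O)[C@H](OS(=O)(=O)O)[C@H]1OS(=O)(=O)O` carries one further sulfo group, the change being (sulfo in place of hydrogen on an oxygen on a saturated carbon), and in this assay compound 3 gives 95 nM. The step of a 1.5-fold higher number from compound 1 to compound 3 (0.19 log units; within the scatter) leaves the two compounds indistinguishable within the usual scatter.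

Compound 2 `CC(=O)N[C@H]1[C@@H](OC[C@@H](O)[C@@H](O)[C@H](O)[C@@H](O)CNc2cccc(NC(=O)CCCCC3CCSS3)c2)O[C@H](COS(=O)(=O)O)[C@H](O)[C@@H]1O[C@@H]1O[C@H](C(=O)O)[C@@H](O)[C@H](OS(=O)(=O)O)[C@H]1O` has a differently placed set of sulfo groups; how its core differs from that of compound 1 is not broken down here. In this assay compound 2 gives 147 nM, the highest of the three numbers, beyond the scatter only against compound 1.

Compound 4 `CC(=O)N[C@H]1[C@@H](OC[C@@H](O)[C@@H](O)[C@H](O)[C@@H](O)CNc2cccc(NC(=O)CCCCC3CCSS3)c2)O[C@H](COS(=O)(=O)O)[C@H](OS(=O)(=O)O)[C@@H]1O[C@@H]1O[C@H](C(=O)O)[C@@H](O)[C@H](OS(=O)(=O)O)[C@H]1O` is derived from compound 2 by the same change, (sulfo in place of hydrogen on an oxygen on a saturated carbon), that turns compound 1 into compound 3. Because a 1.5-fold higher number from compound 1 to compound 3 (0.19 log units; within the scatter) was within the scatter, the expected step of a 1.3-fold higher number from compound 2 to compound 4 (0.11 log units; within the scatter) is of similar modest size. The value expected for compound 4 in this assay is therefore 190 nM, between 90 nM and 420 nM.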

Compound 4, dissociation constant: 60 nM
The estimate for compound 4 lay 3.2-fold (0.50 log units) above the measured number; measured number outside the range, below it.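

In this assay, the change from hydroxy to sulfooxy on the core of compound 2 gives a 2.5-fold lower number from compound 2 to compound 4 (0.39 log units; beyond the scatter), a shift towards tighter binding that exceeds the usual scatter. Set beside the same change on the core of compound 1, this shows that the step did not carry over from one core to the other with a fixed size or direction: the same change on two cores in this assay, a 1.5-fold higher number (0.19 log units; within the scatter) from compound 1 to compound 3 and a 2.5-fold lower number (0.39 log units; beyond the scatter) from compound 2 to compound 4, 3.8-fold (0.57 log units) apart, beyond the scatter of two such steps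

These two pairs show that the outcome of this change differs between the two cores in this series, but they do not show what produces the difference, nor how the change would behave on any further core. The compounds shown leave open whether a phosphate in place of the sulfooxy group would follow either step. They also leave open whether either step would hold with a longer chain on the disulfide-carrying amide.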